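The source may report more compounds than this note shows. Statements on the series, on what has been measured and on what is new or still open speak of the compounds shown alone.

For the measured compounds named here, compound 1 `CCCN(C)c1nc(N)c(C(=O)N=C(N)N)nc1Cl` is the only compound of this set with a number in an assay for inhibition of acid-sensing ion channel 3 (Homo sapiens), read by patch clamp, tested at 1 uM; a lower number here means less inhibition, a higher number more inhibition at the concentration tested (going by the name of the read-out). In this assay compound 1 gives 32%. Compound 2 `CN(c1nc(N)c(C(=O)N=C(N)N)nc1Cl)C1CCCCC1` shares the same core, but in this assay compound 2 gives "not determined" (no result reported), so it offers nothing to compare against. Compound 1 therefore stands alone as the reference point, with no neighbouring values to show which changes on the core shift the inhibition and which leave it alone.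

Compound 3 `CSc1nc(N)c(C(=O)N=C(N)N)nc1Cl` has not been measured. It differs from compound 1 in one place: methylsulfanyl in place of methyl(propyl)amino on an aromatic carbon. Going by the values given here, no measured pair in this set shows what such an exchange does in this assay, so nothing in the data fixes the direction of the step.

Among the compounds with values here, with a single reference value and no measured step to lean on, the expectation is a cautious one. A downward step of moderate size is expected in this assay, a number 10 percentage points lower from compound 1 to compound 3 (within the scatter), though a result within the scatter of compound 1 would not be surprising. Compound 3 is accordingly expected to give 22% in this assay, with a range from 8% to 40%.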

Compound 3, a percentage reported as inhibition, at one concentration (the size of the read-out at that concentration, not a potency): 12%
Compound 3: the middle estimate sits 10 percentage points above what was measured; low and high end bracket the measured number.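

For the compounds shown here, the exchange of methyl(propyl)amino for methylsulfanyl provides the first measured step in this set: in this assay, it gives a number 20 percentage points lower from compound 1 to compound 3 (beyond the scatter), showing that inhibition at the concentration tested responds to what this aromatic carbon, next to the ring nitrogen and ortho to a chloro group, carries. The step combines more than one difference, since the leaving group has 5 heavy atoms (4 carbon, 1 nitrogen) and the entering group has 2 (1 carbon, 1 sulfur), while both have the same counted hydrogen-bond donors and acceptors, so this single pair cannot assign the fall to either the smaller group or the exchange of nitrogen for sulfur. No measurement shown here accounts for the difference between these two groups.

Going by these compounds, it remains open whether the size of the group or the atom attached to the ring matters more, which a propylsulfanyl group or a dimethylamino group at this position would help to separate. A methoxy group or a free amine would further show whether the trend extends beyond this one pair.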